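This account rests on a few compounds, and the source may have more. Where it says the series, first, only, none or still open, it means among the compounds named here.

Compound 1 `CNc1nc2c(N)ncnc2n1[C@@H]1O[C@H](CN(C)CCCCON)[C@@H](O)[C@H]1O` is measured in an assay on isolated protein for inhibition of S-adenosylmethionine decarboxylase proenzyme (Homo sapiens) (on this read-out lower numbers stand for stronger inhibition and higher numbers for weaker inhibition), where compound 1 gives 49 nM, the lowest of the two numbers in hand. Within the data shown here, its only measured neighbour, compound 2 `CNc1nc2c(N)ncnc2n1[C@@H]1O[C@H](CN(C)CCCN)[C@@H](O)[C@H]1O`, gives 440000 nM in this assay, and that step, a 9000-fold higher number from compound 1 to compound 2 (3.95 log units; beyond the scatter), concerns the chain alone. Compound 3 `CN(CCCCON)C[C@H]1O[C@@H](n2c(O)nc3c(N)ncnc32)[C@H](O)[C@@H]1O` differs from compound 1 in another part of the molecule: hydroxy in place of methylamino on an aromatic carbon. Among the measured compounds shown here, no measured step touches this aromatic carbon, so the one known step gives no direct guide. For the change to compound 3 a modest rise in the number is expected, a 3.1-fold higher number from compound 1 to compound 3 (0.49 log units; beyond the scatter). Compound 3 is estimated at 150 nM, within 30 nM to 1500 nM.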

Compound 3, half-maximal inhibitory concentration: 11 nM
The estimate for compound 3 lay 14-fold (1.13 log units) above the measured number, and the stated range ends above it.
By their numbers in this assay, from the lowest: compound 3; then compound 1; then compound 2.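

Putting hydroxy in place of methylamino on this aromatic carbon, between two ring nitrogen atoms, gives a 4.5-fold lower number from compound 1 to compound 3 (0.65 log units; beyond the scatter), so strong inhibition does not depend on the methylamino group here. This change on the core moves the number far less than the chain change did, a 9000-fold higher number from compound 1 to compound 2 (3.95 log units; beyond the scatter). Nothing available explains the drop. As far as these compounds go, it remains open how an amino or methoxy group on this carbon would compare with hydroxy. From the compounds shown here alone, it also remains open whether hydroxy would lower the number with the chain of compound 2.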